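Arginine ester in place of threonine ester on a tetrahydropyranyl core

The compounds below may be only part of what the source reports. "The series", "measured", "known", "first", "only" and "open" are said of these compounds alone.

Measured compounds:
compound 1, `C[C@@H](O)[C@H](NC(=O)CN(c1nc(Cl)nc2[nH]cnc12)C1CC1)C(=O)OCc1ccccc1`, 21.9%
compound 2, `N=C(N)NCCC[C@H](NC(=O)CN(c1nc(Cl)nc2[nH]cnc12)C1CC1)C(=O)OCc1ccccc1`, 23.2%
compound 3, `C[C@@H](O)[C@H](NC(=O)CN(c1ncnc2c1ncn2C1CCCCO1)C1CC1)C(=O)OCc1ccccc1`, 23.6%

In a functional assay on the whole organism (Tail, strain ICR) with Mus musculus as the target, in the tail flick test, with a stated time of 30 min, at a dose of 25 umol/kg by the oral route (a lower number here means a weaker effect, a higher number a stronger effect of the compound at the dose given), compound 1 gives 21.9%, compound 2 gives 23.2% and compound 3 gives 23.6%. All three numbers sit close together: compound 3 stands within the scatter of compound 2 and within the scatter of compound 1, so none of the three can be set apart from the others on this evidence.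

Compound 4, `N=C(N)NCCC[C@H](NC(=O)CN(c1ncnc2c1ncn2C1CCCCO1)C1CC1)C(=O)OCc1ccccc1`, has not yet been measured in this assay. It differs from compound 3 in one place: a group of 7 heavy atoms (4 carbon, 3 nitrogen; no ring) in place of a group of 3 heavy atoms (2 carbon, 1 oxygen; no ring), on a saturated chain carbon bound to an amide-type nitrogen and a carbonyl carbon

The same exchange has been seen once before, on the chlorinated core, as the step from compound 1 to compound 2, where a number 1.3 percentage points higher from compound 1 to compound 2 (within the scatter). That single precedent gives no sign that the exchange moves the read-out beyond the scatter. On the core of compound 3, therefore, no step beyond the scatter is expected either; the estimated step of a number 1.4 percentage points higher from compound 3 to compound 4 (within the scatter) is meant only as a small drift.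

Compound 4 is accordingly expected to give about 25% in this assay, with a likely range from 14% to 36%.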

Compound 4, a percentage reported as activity, at one dose (the size of the read-out at that dose, not a potency): 34.3%
For compound 4 the middle estimate is 9.3 percentage points below the measured one; the range from low to high includes it.
By their numbers in this assay, from the lowest: compounds 1, 2 and 3 (each within the scatter of the next); then compound 4.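

In this assay, the saturated chain carbon bound to an amide-type nitrogen and a carbonyl carbon proves to be a place where this exchange can matter: the 7-heavy-atom chain in place of 1-hydroxyethyl gives a number 10.7 percentage points higher from compound 3 to compound 4 (beyond the scatter). Among these compounds, the exchange had earlier given only a number 1.3 percentage points higher from compound 1 to compound 2 (within the scatter), so this is the first step at this position that lies beyond the scatter, although it is a modest one. It does not establish that the two cores respond differently, since the gap between the two steps is itself within the scatter of two such steps: the same change on two cores in this assay, a number 1.3 percentage points higher (within the scatter) from compound 1 to compound 2 and a number 10.7 percentage points higher (beyond the scatter) from compound 3 to compound 4, 9.4 percentage points apart, within the scatter of two such steps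

The compounds shown leave open whether the step on the core of compound 3 depends on the whole entering chain or only on its end, a question that a simple amine or a carboxylic acid at the end of a chain in this place could begin to answer. Also open, going by these compounds, is whether the exchange would give a step beyond the scatter on a third core, or whether the larger step on the core of compound 3 would hold up on repeated measurement.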